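A few compounds are considered here, and "the series" means these few. Any claim that something is new, unique, unknown or untested is made for them only; others in the source may bear on it.

Measured in a functional assay (blood) for inhibition, with Homo sapiens as the target; a lower number here means a stronger inhibitor, a higher number a weaker inhibitor:
- compound 1 `CC(C)(C)Sc1c(CC(C)(C)C(=O)O)n(Cc2ccc(Cl)cc2)c2ccc(CCc3ccc4ccccc4n3)cc12`: > 3000 nM (a limit, not a number)
- compound 2 `CC(C)(C)Sc1c(CC(C)(C)C(=O)O)n(Cc2ccc(Cl)cc2)c2ccc(OCc3ccc4cccnc4n3)cc12`: > 3000 nM (a limit, not a number)
- compound 3 `CC(C)(C)Sc1c(CC(C)(C)C(=O)O)n(Cc2ccc(Cl)cc2)c2ccc(OCc3nc4ccccc4s3)cc12`: 260 nM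

Compound 3 alone has an actual number, 260 nM. Compound 4 `CC(C)(C)Sc1c(CC(C)(C)C(=O)O)n(Cc2ccc(Cl)cc2)c2ccc(OCc3cccc(Cl)n3)cc12` carries 6-chloropyridin-2-yl in place of 1,3-benzothiazol-2-yl on a saturated chain carbon bound to an oxygen on an aromatic ring. The closest measured change is an at least 11-fold lower number from compound 2 to compound 3 (1.06 log units; beyond the scatter), a large step from a swap at this same place. The change an at least 11-fold lower number from compound 1 to compound 3 (1.06 log units; beyond the scatter) is also large, but it alters the link as well. Neither tests a single-ring group, so the estimate is loose. Losing the 1,3-benzothiazol-2-yl group is expected to give a 2.7-fold higher number from compound 3 to compound 4 (0.43 log units; beyond the scatter), towards a higher number. Compound 4 is estimated at 700 nM, within 150 nM to 3000 nM.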

Compound 4, half-maximal inhibitory concentration: 410 nM
Estimate against measurement, compound 4: 1.7-fold (0.23 log units) above; low and high end bracket the measured number.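

In this assay, a single ring, 6-chloropyridin-2-yl, can replace the two-ring 1,3-benzothiazol-2-yl at this place with no change beyond the scatter (a 1.6-fold higher number from compound 3 to compound 4 (0.20 log units; within the scatter)). So the second ring of 1,3-benzothiazol-2-yl is not needed here for a number in this range. The other two readable steps (an at least 7.3-fold lower number from compound 2 to compound 4 (0.86 log units; beyond the scatter); an at least 7.3-fold lower number from compound 1 to compound 4 (0.86 log units; beyond the scatter)) start from a limit, not a number: the limit of > 3000 nM in this assay, at which 2 of the 4 values shown sit.

As far as these compounds go, what the chlorine itself contributes remains open. So does whether a methoxy group or an amine in its place would keep the number.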